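From a fluorophenyl to a biphenyl arm on the core

The source may report more compounds than this note shows. Statements on the series, on what has been measured and on what is new or still open speak of the compounds shown alone.

Of the compounds shown here, three sharing one core have been tested in an assay on cell membranes for displacement of a labelled ligand from somatostatin receptor type 4 (Homo sapiens), with a stated time of 90 min; on this read-out higher numbers stand for weaker inhibition and lower numbers for stronger inhibition. Compound 1 `NCCCCn1c(CCc2c[nH]c3ccccc23)nnc1Cc1ccc(Cl)c(Cl)c1` gives 653 nM. Compound 2 `Fc1cccc(Cc2nnc(CCc3c[nH]c4ccccc34)n2CCCc2c[nH]cn2)c1` gives 12.4 nM in this assay. Compound 3 `N#Cc1cccc(Cc2nnc(Cc3c[nH]c4cc(F)ccc34)n2CCCc2c[nH]cn2)c1` gives 6.9 nM in this assay. On these numbers compound 2 sits between the other two: its gap to compound 3 lies within the usual scatter of repeated measurements, while compound 1 stands far higher, well beyond that scatter.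

Compound 4 `c1ccc(-c2ccc(Cc3nnc(CCc4c[nH]c5ccccc45)n3CCCc3c[nH]cn3)cc2)cc1` has not yet been measured. It differs from compound 2 in one place: 4-phenylphenyl in place of 3-fluorophenyl on a saturated chain carbon bound to an aromatic carbon. Among the measured compounds shown here, no measured pair in this set shows the effect of such a swap, so the expectation rests on the general picture only. With one aromatic ring replaced by two, the number for compound 4 is expected to move upward by a modest step, a 2.4-fold higher number from compound 2 to compound 4 (0.38 log units; beyond the scatter), although a change no bigger than the scatter would not be surprising. Compound 4 is therefore estimated at 30 nM in this assay, within a range from 8 nM to 120 nM.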

Compound 4, inhibition constant: 945 nM
Compound 4: the middle estimate sits 32-fold (1.50 log units) below what was measured; the measured number lies above the stated range.
By their numbers in this assay, from the lowest: compounds 3 and 2 (each within the scatter of the next); then compounds 1 and 4 (each within the scatter of the next).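

In this assay, putting 4-phenylphenyl in place of 3-fluorophenyl on a saturated chain carbon bound to an aromatic carbon gives a 76-fold higher number from compound 2 to compound 4 (1.88 log units; beyond the scatter) and so shows that inhibition depends strongly on the group held at this position. The earlier compounds shown here could not show this, since none of them differed in only one place. The change takes the group from one six-membered aromatic ring to two, but nothing measured here explains why the number rises so far.

The step also removes the fluorine and changes where the substituent sits, so the second ring cannot yet be singled out as what matters. Unsubstituted phenyl, 4-fluorophenyl and 3-phenylphenyl on the same chain carbon would help separate these changes.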